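From an Amino Side Chain to a Piperidine Ring

The source may hold more compounds than are shown below. What is called first, only, known or untested is meant among the compounds shown, and "the series" means these compounds.

Compound 1 `NCCOc1ccc([C@H]2CC[C@]3(CC2)OOC2(O3)C3CC4CC(C3)CC2C4)cc1`: 287 nM
Compound 2 `CC(C)(O)CNCCCOc1ccc([C@H]2CC[C@]3(CC2)OOC2(O3)C3CC4CC(C3)CC2C4)cc1`: 1210 nM
Compound 3 `CC(C)(N)CCOc1ccc([C@H]2CC[C@]3(CC2)OOC2(O3)C3CC4CC(C3)CC2C4)cc1`: 1050 nM

These maximal plasma concentrations come from an ADME assay on the whole organism (strain FVB) for pharmacokinetics, with Mus musculus as the target, read by LC-MS, at a dose of 30 mg/kg by the oral route; a higher number here means more compound in the circulation at the dose given, a lower number less compound in the circulation. Compound 2 stands at 1210 nM, level with the other high value in the set, as the gap is a 1.2-fold lower number from compound 2 to compound 3 (0.06 log units; within the scatter). Both high values are clearly separated from the lowest, with a 4.2-fold higher number from compound 1 to compound 2 (0.62 log units; beyond the scatter) and a 3.7-fold higher number from compound 1 to compound 3 (0.56 log units; beyond the scatter), each a modest step.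

Compound 4 `c1cc([C@H]2CC[C@]3(CC2)OOC2(O3)C3CC4CC(C3)CC2C4)ccc1OCC1CCNCC1` keeps the shared core, and its structure differs from that of compound 2 as follows: piperidin-4-yl in place of 2-((2-hydroxy-2-methylpropyl)amino)ethyl on a saturated chain carbon bound to an oxygen on an aromatic ring. For the measured compounds named here, no measured step involves a ring at this place, so the three steps offer only indirect guidance. Compound 1, at 287 nM, and compound 2 give the most relevant reference points, and a value between them seems the likeliest outcome. In this assay the expected change is a small downward one, a 1.9-fold lower number from compound 2 to compound 4 (0.27 log units; within the scatter). For compound 4 the estimated value is 650 nM, with an expected range of 200 nM to 1800 nM.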

Compound 4, maximal plasma concentration: 465 nM
For compound 4 the middle estimate is 1.4-fold (0.15 log units) above the measured one; the range from low to high includes it.
By their numbers in this assay, from the lowest: compounds 1 and 4 (each within the scatter of the next); then compounds 3 and 2 (each within the scatter of the next).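

In this assay, a ring at this place, on a saturated chain carbon bound to an oxygen on an aromatic ring, does not match the two open chains (a 2.6-fold lower number from compound 2 to compound 4 (0.42 log units; beyond the scatter); a 2.3-fold lower number from compound 3 to compound 4 (0.35 log units; beyond the scatter)). Against the aminomethyl of compound 1, the piperidin-4-yl group stays within the scatter (a 1.6-fold higher number from compound 1 to compound 4 (0.21 log units; within the scatter)), so compound 4 stands level with compound 1. Among these compounds, then, the extra carbons that go with the higher numbers of compound 2 and compound 3 do not go with one when they are tied into this ring, and no evidence at hand accounts for this.

Open, as far as these compounds go, is whether a 2-hydroxy-2-methylpropyl group on the piperidine nitrogen would bring the number back toward that of compound 2. Also open, from the compounds shown here alone, is how a morpholine ring at this place would compare.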